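Swapping a Formylaminomethyl Arm for a Three-Atom Amidine-Type Group

The compounds below may be only part of what the source reports. "The series", "measured", "known", "first", "only" and "open" are said of these compounds alone.

The measured compounds so far:
compound 1, `Cn1nc2c(=O)n(CC3(O)CCN(Cc4ccc(-c5ccco5)cc4Cl)CC3)cnc2c1-c1ccc(CNC=O)cc1`, 20.9 nM;
compound 2, `Cn1nc2c(=O)n(CC3(O)CCN(Cc4ccc(C5CCCO5)cc4Cl)CC3)cnc2c1-c1ccc(CN)cc1`, 3820 nM;
compound 3, `Cn1cc(-c2ccc(CN3CCC(O)(Cn4cnc5c(-c6ccc(CN)cc6)n(C)nc5c4=O)CC3)c(Cl)c2)cn1`, 291 nM.

All three were tested in an assay on isolated protein for inhibition of ubiquitin carboxyl-terminal hydrolase 7 (Homo sapiens), with stated times of 30 min and 2 h; a higher number here means a weaker inhibitor, a lower number a stronger inhibitor. Compound 1 gives the lowest number of the three: compound 3 sits above it and compound 2 sits far above it, and both gaps lie beyond the usual scatter, so compound 1 is the strongest inhibitor measured here. Among the measured compounds shown here, the only single-place step among the measured compounds is a 13-fold lower number from compound 2 to compound 3 (1.12 log units; beyond the scatter); it concerns the group at the far end of the benzyl arm, not the side of the core that is about to be changed.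

The new compound, compound 4, `Cn1nc2c(=O)n(CC3(O)CCN(Cc4ccc(-c5ccco5)cc4Cl)CC3)cnc2c1-c1ccc(C(=N)N)cc1`, differs from compound 1 in one place: a group of 3 heavy atoms (1 carbon, 2 nitrogen; no ring) in place of a group of 4 heavy atoms (2 carbon, 1 nitrogen, 1 oxygen; no ring), on an aromatic carbon. The change sits on the aromatic carbon of a six-membered aromatic ring of carbon only, para to a large group.

For the measured compounds named here, no measured step bears directly on this replacement. Compound 2, which carries a plain aminomethyl at this position, is weak, but it also differs from compound 1 elsewhere, so its number cannot be assigned to this position alone. A modest weakening is therefore expected for compound 4, a 2.4-fold higher number from compound 1 to compound 4 (0.38 log units; beyond the scatter), with wide uncertainty. Compound 4 is estimated at 50 nM, within 8 nM to 300 nM.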

Compound 4, half-maximal inhibitory concentration: 87.5 nM
For compound 4 the middle estimate is 1.8-fold (0.24 log units) below the measured one, within the range that was stated.
By their numbers in this assay, from the lowest: compound 1; then compound 4; then compound 3; then compound 2.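

In this assay, among the compounds shown here, the result gives the first single-place reading at this position, since the only earlier step lay elsewhere in the molecule. The step is a 4.2-fold higher number from compound 1 to compound 4 (0.62 log units; beyond the scatter): placing this group of 3 heavy atoms on the aromatic carbon in place of the (formylamino)methyl weakens inhibition modestly, but a clearly measurable inhibitor remains. The two groups differ in more than one counted feature, as the entering group has 2 hydrogen-bond donors against 1 in the leaving group and also has one heavy atom fewer, and nothing measured here separates these differences or explains the loss.

The compounds shown do not reveal how a nitrile, a carboxylic acid or a longer chain such as (acetylamino)methyl would behave on this aromatic carbon, so the range of groups accepted at this position remains unmapped. The plain aminomethyl of compound 2 cannot be set against either group on this evidence, as compound 2 differs from compound 1 in more than one place, and a direct comparison would need an aminomethyl on an otherwise unchanged compound 1.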